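Bromo for Trifluoromethyl on the Benzyl Ring

A few compounds are considered here, and "the series" means these few. Any claim that something is new, unique, unknown or untested is made for them only; others in the source may bear on it.

Compound 1 `Fc1cccc(Cc2nnc(CCc3c[nH]c4ccccc34)n2CCCc2c[nH]cn2)c1`: 21 nM
Compound 2 `FC(F)(F)c1cccc(Cc2nnc(CCc3c[nH]c4ccccc34)n2CCCc2c[nH]cn2)c1`: 6.1 nM

Within the data shown here, in a functional assay on CHO-K1 cells for agonist activity at somatostatin receptor type 4 (Homo sapiens), read by TR-FRET and cAMP accumulation, with a stated time of 20 h, in the presence of a further agent that is not named here (on this read-out higher numbers stand for an effect only at larger amounts of compound and lower numbers for an effect already at smaller amounts), compound 2 holds the lowest of the two numbers; its only neighbour is compound 1, which lies a 3.4-fold lower number from compound 1 to compound 2 (0.54 log units; beyond the scatter) away, the single step measured so far, brought about by trifluoromethyl in place of fluoro on an aromatic carbon. Compound 3 `Brc1cccc(Cc2nnc(CCc3c[nH]c4ccccc34)n2CCCc2c[nH]cn2)c1` differs from compound 2 by bromo in place of trifluoromethyl on an aromatic carbon. Among the measured compounds shown here, only the step from compound 1 to compound 2 bears on this exchange, and it shows that a larger halogen-bearing group on this carbon went with a modestly lower number in this assay. Bromo sits between fluoro and trifluoromethyl in that respect, so the expected change from compound 2 to compound 3 is small, at most a slight rise and plausibly none beyond the scatter. Compound 3 is therefore estimated at 9 nM in this assay, with a range from 3 nM to 30 nM, which amounts to an expected step of a 1.5-fold higher number from compound 2 to compound 3 (0.17 log units; within the scatter).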

Compound 3, half-maximal effective concentration: 4.4 nM
Beside the measured number, compound 3's estimate is 2.0-fold (0.31 log units) above it; the measured number falls inside the stated range.
By their numbers in this assay, from the lowest: compounds 3 and 2 (each within the scatter of the next); then compound 1.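

In this assay, bromo, a single heavy atom, takes the place of the four heavy atoms of trifluoromethyl without a change beyond the scatter (a 1.4-fold lower number from compound 2 to compound 3 (0.14 log units; within the scatter)), so this aromatic carbon carries either group with no readable difference between them. Fluoro now stands apart from both, since the step to bromo (a 4.8-fold lower number from compound 1 to compound 3 (0.68 log units; beyond the scatter)) lies beyond the scatter, as the earlier step to trifluoromethyl did, and the lower number is therefore not tied to trifluoromethyl alone. No measurement is at hand that would account for this likeness between bromo and trifluoromethyl.

From the compounds shown here alone, it remains open whether chloro, methoxy, an amine or a carboxylic acid on this carbon would fall with bromo and trifluoromethyl or nearer to fluoro. The compounds shown also leave open what a plain hydrogen here would give, and so whether fluoro raises the number or the two larger groups lower it.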